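The source may report more compounds than this note shows. Statements on the series, on what has been measured and on what is new or still open speak of the compounds shown alone.

Going by the values given here, compound 1 `Cc1cc(Oc2ccc(/C=N/NC(=S)Nc3ccc(Br)cc3)cc2)ccc1Cl` sits at the top of the three numbers so far in a physicochemical assay for lipophilicity, in phosphate buffer, measured as octanol-water partition, with a stated time of 24 h (a lower number here means a more polar compound, a higher number a more lipophilic compound), where compound 1 gives 7.89. Its nearest neighbour is compound 2 `Cc1cc(Oc2ccc(/C=N/NC(=S)Nc3ccc(Cl)cc3)cc2)ccc1Cl`, which in this assay gives 6.59, a step of a number 1.30 log units lower from compound 1 to compound 2 (beyond the scatter). Compound 3 `Cc1cc(Oc2ccc(/C=N/NC(=S)Nc3ccc(F)cc3)cc2)ccc1Cl` lies furthest away and gives 6.07, a step of a number 1.82 log units lower from compound 1 to compound 3 (beyond the scatter). Between these two, the step of a number 0.52 log units lower from compound 2 to compound 3 (beyond the scatter) is smaller, and all three steps are swaps of one halogen for another on the same aromatic carbon.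

Compound 4 `S=C(N/N=C/c1ccc(Oc2ccc3ccccc3c2)cc1)Nc1ccc(Br)cc1` departs from compound 1 in a different place: naphthalen-2-yl in place of 4-chloro-3-methylphenyl on an oxygen on an aromatic ring. Among the compounds with values here, no measured step touches that oxygen or exchanges one ring for another, so none of the three steps bears directly on the change. The halogen steps show that this assay responds to changes on one ring, but they give no direction for the present exchange. The account therefore expects compound 4 to stay near compound 1, with the step of a number 0.01 log units higher from compound 1 to compound 4 (within the scatter) estimated as within the scatter. For compound 4 the estimate in this assay is 7.9, with a range from 7.1 to 8.7.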

Compound 4, partition coefficient: 6.93
Compound 4: the middle estimate sits 0.97 log units above what was measured; the measured number lies below the stated range.
By their numbers in this assay, from the lowest: compound 3; then compound 2; then compound 4; then compound 1.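

The exchange on an oxygen on an aromatic ring is not silent in this assay: naphthalen-2-yl in place of 4-chloro-3-methylphenyl gives a number 0.96 log units lower from compound 1 to compound 4 (beyond the scatter), so this position moves the number too, and the halogen swaps are no longer the only changes shown to do so. The direction was not one that the counts alone would give, as the entering group has 10 heavy atoms against 8 and two six-membered aromatic rings of carbon only against one, with no hydrogen-bond donors or acceptors on either side, and yet the number goes down in this pair. Nothing measured here accounts for that fall, so its reason stays unexplained.

The single exchange removes the chlorine and the methyl and adds a second ring all at once, and the compounds shown leave open which of these changes carries the step. They also leave open where a plain phenyl, or a ring bearing an amine or a carboxylic acid, would stand on this oxygen in this assay, and whether the halogen steps would hold with naphthalen-2-yl in place.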